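The compounds below may be only part of what the source reports. "The series", "measured", "known", "first", "only" and "open" are said of these compounds alone.

Compound 1 `Cc1oc(=O)oc1COC(=O)c1cccc(NC(=O)[C@@H]2C[C@H](SC3=C(C(=O)O)N4C(=O)[C@H]([C@@H](C)O)[C@H]4[C@H]3C)CN2)c1` is the starting point. In a physicochemical assay for metabolic stability, read by LC-MS, in phosphate buffer, with a stated time of 3 h, at pH 7.4, tested at 50 uM (a higher number here means that more of the compound is left, a lower number that less of the compound is left), compound 1 gives > 95%, which is a limit of the assay and not a number. Two further compounds sharing its core were run in this assay. Compound 2 `COC(=O)C1=C(S[C@@H]2CN[C@H](C(=O)Nc3cccc(C(=O)OC)c3)C2)[C@H](C)[C@@H]2[C@@H]([C@@H](C)O)C(=O)N12` gives > 95% in this assay, again a limit. Compound 3 `Cc1oc(=O)oc1COC(=O)C1=C(S[C@@H]2CN[C@H](C(=O)Nc3cccc(C(=O)OCc4oc(=O)oc4C)c3)C2)[C@H](C)[C@@H]2[C@@H]([C@@H](C)O)C(=O)N12` gives > 95% in this assay, also a limit. The step that the two limits leave unreadable from compound 1 to compound 3 therefore cannot be read, because of the limit of > 95% in this assay, at which 3 of the 3 values shown sit.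

Compound 4 `CC(C)C(=O)OCOC(=O)c1cccc(NC(=O)[C@@H]2C[C@H](SC3=C(C(=O)O)N4C(=O)[C@H]([C@@H](C)O)[C@H]4[C@H]3C)CN2)c1` differs from compound 1 by a group of 6 heavy atoms (4 carbon, 2 oxygen; no ring) in place of a group of 7 heavy atoms (4 carbon, 3 oxygen; one five-membered aromatic ring with 2 hetero atoms), on a saturated chain carbon bound to an oxygen next to a carbonyl group; what leaves is a group with no common name, what enters is (isopropylcarbonyl)oxy, on a saturated chain carbon bound to an oxygen next to a carbonyl group. No measured step bears on this change with a readable size; all that the shown values offer is that every compound so far sits at the limit. Compound 4 is therefore expected to show a step that the limit leaves unreadable from compound 1 to compound 4 in this assay, none beyond the scatter. Compound 4 is estimated at 97% in this assay, between 88% and 100%.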

Compound 4, percent of the compound remaining: > 95%
Compound 4 gave a limit, no number; the forecaster's own chance of this, stated with the estimate: 75%; the middle value lies beyond the limit too.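

No step from compound 1 to compound 4 can be read in this assay, because both values are limits: the limit of > 95% in this assay, at which 4 of the 4 values shown sit.

The compounds shown leave open whether (isopropylcarbonyl)oxy, or any other change among them, alters the percent of compound remaining at all, since none gives a value short of the limit.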